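Isoindolinone amides: chain length at the ring nitrogen

A few compounds are considered here, and "the series" means these few. Any claim that something is new, unique, unknown or untested is made for them only; others in the source may bear on it.

Measured compounds:
compound 1 `O=C(O)CN1Cc2ccc(NC(=O)c3ccc4c(c3)CNCC4)cc2C1=O` — 120000 nM
compound 2 `O=C(O)CN1Cc2ccc(NC(=O)c3ccc(C4CCNCC4)cc3)cc2C1=O` — 24000 nM
compound 3 `O=C(O)CCCN1Cc2ccc(NC(=O)c3ccc4c(c3)CNCC4)cc2C1=O` — 330000 nM

The series was run in a functional assay on a cell-free system (Platelet, plasma, Homo sapiens) for inhibition; a higher number here means a weaker inhibitor, a lower number a stronger inhibitor. Compound 2 gives the lowest number of the three, 24000 nM, and compound 1, the nearest to it, gives 120000 nM; that gap is beyond the scatter. The difference between the cores of compound 1 and compound 2 is not broken down here.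

One change is shared across the set: 2-carboxyethyl in place of carboxy on a saturated chain carbon bound to an amide-type nitrogen in a ring. Made from compound 1, it gave a 2.8-fold higher number from compound 1 to compound 3 (0.44 log units; beyond the scatter), a modest weakening of inhibition.

Compound 4 `O=C(O)CCCN1Cc2ccc(NC(=O)c3ccc(C4CCNCC4)cc3)cc2C1=O` is not yet measured. It carries the same change made on the core of compound 2: 2-carboxyethyl in place of carboxy on a saturated chain carbon bound to an amide-type nitrogen in a ring. The place of the change is the same in both pairs, so this is the same change, not merely the same kind. Going by the values given here, with only one measured instance of the change, the expectation for compound 4 rests on compound 2 and on the step from compound 1 to compound 3: the number for compound 4 is expected to rise from that of compound 2 by about a 2.8-fold higher number from compound 2 to compound 4 (0.45 log units; beyond the scatter), because a 2.8-fold higher number from compound 1 to compound 3 (0.44 log units; beyond the scatter) was seen for the only pair in which this change has been measured. The estimate for compound 4 in this assay is 67000 nM, with a range of 30000 nM to 150000 nM.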

Compound 4, half-maximal inhibitory concentration: 410000 nM
Estimate against measurement, compound 4: 6.1-fold (0.79 log units) below; measured number above the stated range.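

In this assay, going from carboxymethyl to 3-carboxypropyl weakens inhibition on the second core as well, with a 17-fold higher number from compound 2 to compound 4 (1.23 log units; beyond the scatter). The two steps run in the same direction but differ in size: the same change on two cores in this assay, a 2.8-fold higher number (0.44 log units; beyond the scatter) from compound 1 to compound 3 and a 17-fold higher number (1.23 log units; beyond the scatter) from compound 2 to compound 4, 6.2-fold (0.79 log units) apart, beyond the scatter of two such steps

For this series, the change therefore carries from one core to the other in direction but not in magnitude, so a step measured on one core cannot simply be transferred to the other as a number. These two pairs do not show which part of the cores sets the size of the step, nor whether the same holds on any core beyond these two.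

The compounds shown leave open how the number moves with chain length on either core, since only carboxymethyl and 3-carboxypropyl appear here, and a chain of intermediate length or one longer than 3-carboxypropyl would show whether the rise is gradual or abrupt. They also leave open whether the carboxylic acid itself matters to the size of the step, which a methyl ester or a primary amide at the end of the same chains, on both cores, would begin to address.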